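From 3-fluorophenyl to 4-fluorophenyl at the assay limit

The source may hold more compounds than are shown below. What is called first, only, known or untested is meant among the compounds shown, and "the series" means these compounds.

Measured in a functional assay on Jurkat cells (Homo sapiens) for antiproliferative activity, read by MTT assay, with a stated time of 72 h; a lower number here means a stronger inhibitor, a higher number a weaker inhibitor:
Compound 1 `COc1cc(-c2ncnn2-c2cccc(F)c2)cc(OC)c1OC`: > 10000 nM
Compound 2 `COc1ccc(-c2ncnn2-c2cc(OC)c(OC)c(OC)c2)cc1`: 50 nM
Compound 3 `COc1cc(-n2ncnc2-c2ccc(Cl)cc2)cc(OC)c1OC`: > 10000 nM

Compound 1 stands at the limit of > 10000 nM in this assay, at which 2 of the 3 values shown sit. Its entry is a limit and not a number. Compound 3 likewise reports only a limit, so compound 2 is the only one of the three with a measured number.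

Compound 4 `COc1cc(-c2ncnn2-c2ccc(F)cc2)cc(OC)c1OC` has not yet been measured. It differs from compound 1 in a single group: 4-fluorophenyl in place of 3-fluorophenyl on an aromatic nitrogen. In short, it carries 4-fluorophenyl in place of 3-fluorophenyl on an aromatic nitrogen, and the two compounds have the same atoms, joined differently.

For the measured compounds named here, only one measured step bears on this change, and only indirectly: an at least 200-fold higher number from compound 2 to compound 3 (2.30 log units; beyond the scatter). Going by the values given here, that large step was a change of chloro for methoxy on an aromatic carbon, not a change on an aromatic nitrogen, and no measured step involves fluorine. Given an at least 200-fold higher number from compound 2 to compound 3 (2.30 log units; beyond the scatter), a single swap can clearly matter in this assay, so a move toward a lower number cannot be excluded. Still, nothing measured points to one, and the most likely outcome is no step beyond the scatter.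

The expected outcome is little or no change, an estimated a number no higher from compound 1 to compound 4 (the limit leaves the size open). For compound 4 the estimated value is 10000 nM, with an expected range from 2000 nM to 20000 nM.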

Compound 4, half-maximal inhibitory concentration: > 10000 nM
Compound 4 was reported as a limit (the forecaster's own chance of this, stated with the estimate: 70%); the middle value lies on the limit itself.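

In this assay compound 4 gives > 10000 nM, which is a limit and not a number. Compound 1 is also reported only as a limit, so no step between compound 1 and compound 4 can be read: the limit of > 10000 nM in this assay, at which 3 of the 4 values shown sit.

The compounds shown leave open whether 4-fluorophenyl and 3-fluorophenyl on the aromatic nitrogen differ in this assay at all.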